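This account rests on a few compounds, and the source may have more. Where it says the series, first, only, none or still open, it means among the compounds named here.

In an assay on HEK-293T cells for inhibition of phospholipase A and acyltransferase 2 (Homo sapiens), with stated times of 30 min and 20 min (on this read-out lower numbers stand for stronger inhibition and higher numbers for weaker inhibition), compound 1, `O=C(CCc1ccc(Cl)cc1)C(=O)NCCCCc1ccccc1`, gives 631 nM. Compound 2, `CCNC(=O)C(=O)CCc1ccc(Cl)cc1`, differs from it in one place, and in this assay compound 2 gives 2510 nM. The only measured step so far is a 4.0-fold higher number from compound 1 to compound 2 (0.60 log units; beyond the scatter), so among the two numbers shown compound 2 stands highest, meaning it is the weaker inhibitor of the pair, and its nearest neighbour is compound 1.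

Compound 3, `CN(C)C(=O)C(=O)CCc1ccc(Cl)cc1`, is built from the same atoms as compound 2, joined differently: dimethylamino in place of ethylamino on a carbonyl carbon. Among the compounds with values here, no measured step bears on this change. Within the data shown here, the one step available alters a different part of the structure and says nothing about exchanging these two groups on the carbonyl carbon. Without such guidance, the expected step in this assay is small, a 1.3-fold higher number from compound 2 to compound 3 (0.11 log units; within the scatter), and no direction beyond the scatter can be foreseen with confidence. Compound 3 is therefore estimated at 3200 nM, with a range from 1000 nM to 10000 nM to reflect that uncertainty.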

Compound 3, half-maximal inhibitory concentration: > 10000 nM
Compound 3 gave a limit, no number; the forecaster's own chance of this, stated with the estimate: 10%; middle value at least 3.1-fold (0.49 log units) from the limit.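

Moving from ethylamino to dimethylamino on a carbonyl carbon is not a neutral swap in this assay, even though the two groups hold the same heavy atoms: the change gives an at least 3.9-fold higher number from compound 2 to compound 3 (0.60 log units; beyond the scatter). Within the data shown here, compound 1 and compound 2 both keep the amide hydrogen and differ only in the group carried further along the chain, whereas compound 3 is the first compound here without that hydrogen, as ethylamino counts one hydrogen-bond donor and dimethylamino none. The reading for compound 3 is a limit of the assay and not a number, so this step has a floor but no known size, and the result marks the edge of what the assay can report: the limit of > 10000 nM in this assay, at which 1 of the 3 values shown sits.

This single pair cannot separate the loss of the amide hydrogen from the presence of a second methyl on the nitrogen, and it gives no measured reason for the drop. Methylamino, which keeps the amide hydrogen, and a ring amine such as pyrrolidine, which lacks it, remain open at this carbonyl carbon.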